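The compounds below may be only part of what the source reports. "The series", "measured", "known", "first", "only" and "open" are said of these compounds alone.

Working notes on the series

The three measured compounds share one core and differ only in the aryl group on a saturated ring carbon. In a functional assay on Ehrlich cells (Mus musculus) for cytotoxicity (on this read-out higher numbers stand for weaker inhibition and lower numbers for stronger inhibition), compound 1 `COc1cc(N2C(N)=C(C#N)C(c3ccc([N+](=O)[O-])cc3)C3=C2CC(C)(C)CC3=O)cc(OC)c1OC` gives 25000 nM, compound 2 `COc1cc(N2C(N)=C(C#N)C(c3c(O)ccc4ccccc34)C3=C2CC(C)(C)CC3=O)cc(OC)c1OC` gives 143000 nM, and compound 3 `COc1cc(N2C(N)=C(C#N)C(c3ccc(Cl)cc3Cl)C3=C2CC(C)(C)CC3=O)cc(OC)c1OC` gives 94700 nM. Compound 3 stands second highest of the three numbers: the step of a 3.8-fold higher number from compound 1 to compound 3 (0.58 log units; beyond the scatter) is beyond the scatter, while the step of a 1.5-fold lower number from compound 2 to compound 3 (0.18 log units; within the scatter) is within it, so compound 2 and compound 3 cannot be ordered against each other. The step of a 5.7-fold higher number from compound 1 to compound 2 (0.76 log units; beyond the scatter) is also beyond the scatter.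

Compound 4 `COc1cc(N2C(N)=C(C#N)C(c3ccc(O)cc3)C3=C2CC(C)(C)CC3=O)cc(OC)c1OC` is the next member, not yet measured. The change is 4-hydroxyphenyl in place of 2,4-dichlorophenyl on a saturated ring carbon. Going by the values given here, both measured steps away from compound 1 raised the number, but no measured step swaps one substituted phenyl for another substituted phenyl that carries a hydrogen-bond donor, so the two relevant steps give only a loose frame. A step of modest size in this assay, in either direction, is therefore expected, with a lower number somewhat more likely since compound 1 shows that a group in the same place can give 25000 nM.

For compound 4 the expected value in this assay is 60000 nM, within 20000 nM to 180000 nM, which would mean an estimated step of a 1.6-fold lower number from compound 3 to compound 4 (0.20 log units; within the scatter).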

Compound 4, half-maximal inhibitory concentration: 75800 nM
Compound 4: middle estimate off by 1.3-fold (0.10 log units), on the low side; the range from low to high includes it.
By their numbers in this assay, from the lowest: compound 1; then compounds 4, 3 and 2 (each within the scatter of the next).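

In this assay 4-hydroxyphenyl cannot be told apart on this saturated ring carbon from 2,4-dichlorophenyl (a 1.2-fold lower number from compound 3 to compound 4 (0.10 log units; within the scatter)) or from 2-hydroxynaphthalen-1-yl (a 1.9-fold lower number from compound 2 to compound 4 (0.28 log units; within the scatter)), since both steps lie within the scatter, even though the group entering in compound 4 carries a hydrogen-bond donor and a hydrogen-bond acceptor and the 2,4-dichlorophenyl group carries neither. Going by these compounds alone, the one step that swaps a single group on the aromatic carbon, hydroxy in place of nitro (a 3.0-fold higher number from compound 1 to compound 4 (0.48 log units; beyond the scatter)), lies beyond the scatter, so compound 1 now stands apart from all three other compounds as the lowest number of the four, and the differences among those three cannot be read. Nothing available gives a reason for either finding.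

It remains open whether the separation of compound 1 is specific to the nitro group, as the compounds shown offer no other group in its place on the phenyl ring, such as an amine, a carboxylic acid or a methoxy group. The 3,4,5-trimethoxyphenyl group also stays the same throughout, which leaves open whether these steps would hold with another group there, such as a benzyl group.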